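The source may report more compounds than this note shows. Statements on the series, on what has been measured and on what is new or still open speak of the compounds shown alone.

Measured so far in a functional assay on MCF7 cells (Homo sapiens) for cytotoxicity, read by MTT assay, with a stated time of 72 h; a lower number here means a stronger inhibitor, a higher number a weaker inhibitor:
compound 1, `COc1cccc(/C=C2\CCC/C(=C\c3ccc(O)c(Cl)c3)C2=O)c1OC`: 16400 nM
compound 2, `COc1cc(/C=C2\CCC/C(=C\c3cccc(OC)c3OC)C2=O)ccc1O`: 11600 nM
compound 3, `COc1ccccc1/C=C1\CCC/C(=C\c2ccc(OC)c(OC)c2)C1=O`: 8000 nM

Compound 3 gives the lowest of the three numbers. Its gap to compound 2 falls within the scatter, so the two cannot be ordered; its gap to compound 1 lies beyond the scatter. Among the compounds with values here, the only step between measured compounds that differ in a single place is a 1.4-fold lower number from compound 1 to compound 2 (0.15 log units; within the scatter), an exchange of one substituent that did not move the number beyond the scatter.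

Compound 4, `COc1ccc(/C=C2\CCC/C(=C\c3ccc(O)c(O)c3)C2=O)cc1OC`, has not been measured in this assay. It differs from compound 3 as follows: 3,4-dihydroxyphenyl in place of 2-methoxyphenyl on a double-bonded chain carbon bound to a double-bonded ring carbon. Within the data shown here, no measured pair shows this exchange, and no measured pair replaces one whole aryl group with another, so no step bears directly on it. Among the measured compounds shown here, the one single-place step seen, a swap of one aromatic substituent, sat within the scatter; nothing argues for a movement beyond the scatter in either direction. Compound 4 is therefore expected near compound 3, the estimated step being a 1.1-fold lower number from compound 3 to compound 4 (0.03 log units; within the scatter). For the measured compounds named here, the estimate for compound 4 is 7500 nM, with a range from 2500 nM to 22000 nM; the range is wide, the exchange having no precedent.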

Compound 4, half-maximal inhibitory concentration: 14400 nM
Compound 4: the middle estimate sits 1.9-fold (0.28 log units) below what was measured; low and high end bracket the measured number.
By their numbers in this assay, from the lowest: compounds 3, 2, 4 and 1 (each within the scatter of the next, the first and the last beyond it).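

In this assay, one whole aryl group on a double-bonded chain carbon bound to a double-bonded ring carbon is now exchanged for another, and the result is a 1.8-fold higher number from compound 3 to compound 4 (0.26 log units; within the scatter) for 3,4-dihydroxyphenyl in place of 2-methoxyphenyl. At this place, then, a group with 2 hydrogen-bond donors can replace one with 0 without a shift beyond the scatter, even though the whole substitution pattern of the aryl group changes, which extends the earlier single-substituent result to a much larger exchange. No measurement in hand accounts for the step, and its size gives no ground for assigning an effect to either group.

The exchange removes one methoxy group and brings in two hydroxy groups in a single move, so the compounds shown do not separate the contribution of each hydroxy group or of the lost methoxy group. Also open, going by these compounds, is whether this place tolerates aryl groups carrying a different kind of substituent, such as an amine or a carboxylic acid, as it tolerates the oxygen-bearing groups seen so far.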